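A few compounds are considered here, and "the series" means these few. Any claim that something is new, unique, unknown or untested is made for them only; others in the source may bear on it.

Measured in a functional assay on A549 cells (Homo sapiens) for cytotoxicity; a lower number here means a stronger inhibitor, a higher number a weaker inhibitor:
compound 1 `C=C/C=C\[C@H](C)[C@H](OC(N)=O)[C@@H](C)[C@H](O)[C@@H](C)C/C(C)=C\[C@H](C)[C@@H](O)[C@@H](C)/C=C\CCc1cccc(Cl)c1` gives 580 nM
compound 2 `C=C/C=C\[C@H](C)[C@H](OC(N)=O)[C@@H](C)[C@H](O)[C@@H](C)C/C(C)=C\[C@H](C)[C@@H](O)[C@@H](C)/C=C\CCc1ccc(Oc2ccccc2)cc1` gives 10000 nM
compound 3 `C=C/C=C\[C@H](C)[C@H](OC(N)=O)[C@@H](C)[C@H](O)[C@@H](C)C/C(C)=C\[C@H](C)[C@@H](O)[C@@H](C)/C=C\CCc1cccc(OC)c1` gives 600 nM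

Compound 3 holds the second highest of the three numbers. Its nearest neighbour is compound 1, and the step of a 1.0-fold higher number from compound 1 to compound 3 (0.01 log units; within the scatter) lies within the scatter, so the two values cannot be ordered. Compound 2 stands furthest from compound 3, beyond the scatter.

Compound 4 `C=C/C=C\[C@H](C)[C@H](OC(N)=O)[C@@H](C)[C@H](O)[C@@H](C)C/C(C)=C\[C@H](C)[C@@H](O)[C@@H](C)/C=C\CCc1sccc1C` differs from compound 3 by 3-methylthiophen-2-yl in place of 3-methoxyphenyl on a saturated chain carbon, two bonds along the chain from a double-bonded chain carbon. Among the compounds with values here, the single measured step, a 1.0-fold higher number from compound 1 to compound 3 (0.01 log units; within the scatter), exchanges one substituent for another on the same aromatic ring and stays within the scatter; no measured step replaces the ring itself, so the measured data bear on this change only loosely. Compound 2, which carries a different group at the same place, gives the highest number, a reminder that changes there can reach beyond the scatter. On balance no step beyond the scatter is expected, but with a wide range. Compound 4 is expected to give about 750 nM, between 250 nM and 2500 nM. The expected step is a 1.3-fold higher number from compound 3 to compound 4 (0.10 log units; within the scatter).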

Compound 4, half-maximal inhibitory concentration: 790 nM
Beside the measured number, compound 4's estimate is 1.1-fold (0.02 log units) below it; the measured number falls inside the stated range.
By their numbers in this assay, from the lowest: compounds 1, 3 and 4 (each within the scatter of the next); then compound 2.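

Until now only substituents on a phenyl ring had been exchanged at this place, whereas compound 4 replaces the aromatic ring itself, and in this assay this gives a 1.3-fold higher number from compound 3 to compound 4 (0.12 log units; within the scatter). Measured against the 3-chlorophenyl group the result is the same in kind, a 1.4-fold higher number from compound 1 to compound 4 (0.13 log units; within the scatter), so the saturated chain carbon carries a 3-methylthiophen-2-yl group as well as either phenyl group, while the group of compound 2 still stands apart at 10000 nM. No evidence is at hand to explain why these three compounds cannot be ordered.

It remains open whether an aromatic ring is needed at this place at all, since the compounds shown say nothing about a simple alkyl chain, an amine or a carboxylic acid there. They also leave open how a pyridine ring would fare.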